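The compounds below may be only part of what the source reports. "The series", "measured", "known", "first", "only" and "open" are said of these compounds alone.

Compound 1 `c1cncc(-c2nc3ccccc3n2C2CC2)c1`: > 8330 nM
Compound 2 `Fc1ccc2nc(-c3cccnc3)n(C3CC3)c2c1`: 401 nM
Compound 3 `Fc1ccc2c(c1)nc(-c1cccnc1)n2C1CC1`: 3980 nM

In an assay on V79 cells for inhibition of cytochrome P450 11B1, mitochondrial (Homo sapiens), read by HTRF, with a stated time of 1 h (on this read-out higher numbers stand for weaker inhibition and lower numbers for stronger inhibition), compound 1 stands only at the limit of > 8330 nM in this assay, at which 1 of the 3 values shown sits, a limit of the assay and not a number. Compound 4 `Fc1cccc2c1nc(-c1cccnc1)n2C1CC1` differs from compound 1 in fluoro in place of hydrogen on an aromatic carbon. Going by the values given here, two measured steps bear on this change: the step of an at least 20-fold lower number from compound 1 to compound 2 (1.31 log units; beyond the scatter) and the step of an at least 2.0-fold lower number from compound 1 to compound 3 (0.32 log units; beyond the scatter), both fluoro in place of hydrogen on an aromatic carbon of the same ring. Both steps lowered the number in this assay, though by differing amounts. An at least modest lowering is therefore expected for compound 4, with the step of an at least 3.3-fold lower number from compound 1 to compound 4 (0.52 log units; beyond the scatter). Compound 4 is estimated at 2500 nM, with a range from 600 nM to 8330 nM.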

Compound 4, half-maximal inhibitory concentration: > 8330 nM
Compound 4: no number, only a limit (the forecaster's own chance of this, stated with the estimate: 25%); at least 3.3-fold (0.52 log units) between middle value and limit.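

Compound 4, like compound 1, gives only a limit of the assay and not a number, so the step between them cannot be read: the limit of > 8330 nM in this assay, at which 2 of the 4 values shown sit.

The compounds shown leave open whether fluoro at this place on compound 4 changes the number in this assay at all.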